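Aryl substitution on the thiosemicarbazide nitrogen: step to compound 4

This account rests on a few compounds, and the source may have more. Where it says the series, first, only, none or still open, it means among the compounds named here.

Measured so far in a functional assay on HeLa cells (Homo sapiens) for antiproliferative activity, read by sulforhodamine B assay, with a stated time of 72 h; a lower number here means a stronger inhibitor, a higher number a weaker inhibitor:
compound 1 `NC(=S)N/N=C/c1ccc2ccccc2n1` gives 960 nM
compound 2 `S=C(N/N=C/c1ccc2ccccc2n1)Nc1ccc(Br)cc1` gives 56800 nM
compound 3 `S=C(N/N=C/c1ccc2ccccc2n1)Nc1ccc(Cl)cc1` gives > 100000 nM

Compound 3 sits at a limit of this assay, not at a number; its value of > 100000 nM is that limit. Of the three values shown, (the limit of > 100000 nM in this assay, at which 1 of the 3 values shown sits). Compound 3 is therefore known only as the weakest end of the set so far: the step of an at least 100-fold higher number from compound 1 to compound 3 (2.01 log units; beyond the scatter) is large and beyond the scatter, while the step of an at least 1.7-fold higher number from compound 2 to compound 3 (0.24 log units; that floor lies within the scatter) has a floor that lies within the scatter, so compound 2 and compound 3 cannot be ordered against each other.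

Compound 4 `COc1ccccc1NC(=S)N/N=C/c1ccc2ccccc2n1` is not yet measured. It differs from compound 3 by 2-methoxyphenyl in place of 4-chlorophenyl on an amide-type nitrogen. Within the data shown here, the steps that bear on this change are those from the unsubstituted parent: a 59-fold higher number from compound 1 to compound 2 (1.77 log units; beyond the scatter) and an at least 100-fold higher number from compound 1 to compound 3 (2.01 log units; beyond the scatter). Both place an aryl group on that nitrogen and both give a large rise in the number. Compound 4 keeps an aryl group there, so the expectation is a number in the same high region as compound 2 and compound 3, with no step beyond the scatter from compound 3 expected in either direction.

Compound 4 is expected to give about 70000 nM in this assay, within 15000 nM to 300000 nM. The step this estimate implies is expected to be an at least 1.4-fold lower number from compound 3 to compound 4 (0.15 log units; that floor lies within the scatter).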

Compound 4, half-maximal inhibitory concentration: > 100000 nM
Compound 4 was reported as a limit; the forecaster's own chance of this, stated with the estimate: 45%; middle value at least 1.4-fold (0.15 log units) away from the limit.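

A third aryl group on the amide-type nitrogen, this time 2-methoxyphenyl, keeps the series in the same high region in this assay: an at least 100-fold higher number from compound 1 to compound 4 (2.01 log units; beyond the scatter) shows that the loss is not confined to 4-bromophenyl and 4-chlorophenyl. The step of an at least 1.7-fold higher number from compound 2 to compound 4 (0.24 log units; that floor lies within the scatter) gives no order among these aryl compounds, and the step between compound 3 and compound 4 cannot be read. The value of compound 4 is a limit and not a number, so any differences among aryl groups on this nitrogen beyond that limit stay hidden: the limit of > 100000 nM in this assay, at which 2 of the 4 values shown sit.

Open, on these data alone, is whether a small alkyl group such as methyl, or a benzyl group, on this nitrogen would stay near compound 1 at 960 nM. Also open, as far as these compounds go, is whether a phenyl ring carrying a dimethylamino group or a carboxylic acid would bring the aryl compounds back within the measurable range of this assay.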